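This account rests on a few compounds, and the source may have more. Where it says the series, first, only, none or still open, it means among the compounds named here.

Measured compounds in the series:
- compound 1, `O=C(O)C[C@H](O)C[C@H](O)/C=C/c1c(C2CC2)nc2sccc2c1-c1ccc(F)cc1`: 38.1%
- compound 2, `Cc1nn(Cc2ccccc2)c2nc(C(C)C)c(/C=C/[C@@H](O)C[C@@H](O)CC(=O)O)c(-c3ccc(F)cc3)c12`: 16.4%
- compound 3, `CC(C)c1nc2cc(-c3ccccc3)nn2c(-c2ccc(F)cc2)c1/C=C/[C@@H](O)C[C@@H](O)CC(=O)O`: -1.4%

All three numbers come from an in vivo functional assay on the whole organism for inhibition of 3-hydroxy-3-methylglutaryl-coenzyme A reductase (Rattus norvegicus), at a dose of 0.2 mg/kg by the oral route; on this read-out higher numbers stand for a stronger effect at the one dose given and lower numbers for a weaker effect. Compound 2 stands second highest of the three. Its nearest neighbour is compound 3, which lies lower by a gap beyond the scatter; compound 1 lies higher by a gap that is also beyond the scatter. For the measured compounds named here, the three compounds share the dihydroxy-acid side chain and the fluorophenyl group but differ in the fused core, so no single-point step between measured compounds is available, and nothing in the measured set speaks directly to the change now considered.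

Compound 4, `Cc1nn(-c2ccccc2)c2nc(C(C)C)c(/C=C/[C@@H](O)C[C@@H](O)CC(=O)O)c(-c3ccc(F)cc3)c12`, is not yet measured in this assay. It differs from compound 2 in one place: phenyl in place of benzyl on an aromatic nitrogen. The change removes one carbon from the group on the aromatic nitrogen and keeps the aromatic ring. Going by the values given here, with no comparable step among the measured compounds, the expected size of the change is small and its direction undecided; the working assumption is a step within the scatter. Compound 4 is therefore expected to give about 18% in this assay, with a range from 4% to 36%. The estimated step is a number 1.6 percentage points higher from compound 2 to compound 4 (within the scatter).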

Compound 4, a percentage reported as inhibition, in the whole organism at one dose (the size of the read-out at that dose, not a potency): 3.3%
Compound 4: the middle estimate sits 14.7 percentage points above what was measured; measured number outside the range, below it.
By their numbers in this assay, from the lowest: compounds 3 and 4 (each within the scatter of the next); then compound 2; then compound 1.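

For the compounds shown here, the first single-place step shows that the group on the aromatic nitrogen is not a neutral position in this assay: phenyl in place of benzyl gives a number 13.1 percentage points lower from compound 2 to compound 4 (beyond the scatter), even though the change is small on paper. The entering group keeps the six-membered aromatic ring and goes only from 7 heavy atoms to 6, with no hydrogen-bond donor, acceptor or net charge on either side, so the presence of the aromatic ring alone does not hold the read-out at the level of compound 2. Nothing measured here bears on why the read-out falls, which leaves the step as an observation at a single oral dose, not a difference in potency.

Still open, on these data alone, is whether the carbon count or the aromatic ring governs this position: a 2-phenylethyl group would extend the chain beyond benzyl, and a cyclohexylmethyl group would keep the chain length of benzyl without the aromatic ring. A methyl group on the same nitrogen would show how far the read-out depends on having a ring there at all.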